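Carbonyl substituent variation in the series

The source may hold more compounds than are shown below. What is called first, only, known or untested is meant among the compounds shown, and "the series" means these compounds.

Measured so far:
compound 1, `Cc1nc(S(C)(=O)=O)ccc1Oc1ncnc(OC2CCN(C(=O)SC3(C)CC3)CC2)c1F`, gives 13.2 nM in a functional assay on isolated protein for inhibition of Glucose-dependent insulinotropic receptor (Homo sapiens), read by HTRF and cAMP accumulation; on this read-out lower numbers stand for an effect already at smaller amounts and higher numbers for an effect only at larger amounts of compound
compound 2, `Cc1nc(S(C)(=O)=O)ccc1Oc1ncnc(OC2CCN(C(=O)C3(F)CCC3)CC2)c1F`, gives 24.7 nM in this assay

Compound 2 holds the higher of the two numbers seen in this assay, but the step of a 1.9-fold higher number from compound 1 to compound 2 (0.27 log units; within the scatter) lies within the scatter, so compounds 1 and 2 cannot be put in order on these data. Compound 3, `CCc1cnc(C(=O)N2CCC(Oc3ncnc(Oc4ccc(S(C)(=O)=O)nc4C)c3F)CC2)nc1`, differs from compound 2 at the carbonyl carbon: a group of 8 heavy atoms (6 carbon, 2 nitrogen; one six-membered aromatic ring with 2 hetero atoms) in place of a group of 5 heavy atoms (4 carbon, 1 fluorine; one four-membered non-aromatic ring of carbon only), on a carbonyl carbon. Among the compounds with values here, the only measured step, a 1.9-fold higher number from compound 1 to compound 2 (0.27 log units; within the scatter), exchanged one small non-aromatic group for another at the same carbonyl carbon and stayed within the scatter; no measured step exchanges a non-aromatic group for an aromatic one at this position, so there is no direct precedent for the entering 5-ethylpyrimidin-2-yl. Within the data shown here, an expectation for compound 3 can rest only on the observation that the one change made at this carbonyl carbon left the number within the scatter; the expected step of a 1.1-fold lower number from compound 2 to compound 3 (0.05 log units; within the scatter) is therefore taken as small, with a wide range open in either direction. Compound 3 is estimated at 22 nM in this assay, with a range from 6 nM to 80 nM.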

Compound 3, half-maximal effective concentration: 4.7 nM
Compound 3: middle estimate off by 4.7-fold (0.67 log units), on the high side; measured number below the stated range.
By their numbers in this assay, from the lowest: compound 3; then compounds 1 and 2 (each within the scatter of the next).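

Within the data shown here, at the carbonyl carbon on the ring amide nitrogen, 5-ethylpyrimidin-2-yl is the only aromatic group among the three compounds, and compound 3 has the lowest number in this assay, with both of its steps beyond the scatter (a 5.3-fold lower number from compound 2 to compound 3 (0.72 log units; beyond the scatter); a 2.8-fold lower number from compound 1 to compound 3 (0.45 log units; beyond the scatter)). This shows that the number does respond to a change at this position, which the exchange between the two non-aromatic groups of compounds 1 and 2 did not show, since that step stayed within the scatter. Nothing measured here bears on what lies behind the two new steps.

With a single aromatic example, the compounds shown do not separate the contribution of the aromatic ring itself from that of its two ring nitrogens or of the ethyl group, so the link between aromatic groups and lower numbers rests on compound 3 alone. Unsubstituted pyrimidin-2-yl, phenyl and 5-methylpyrimidin-2-yl would divide the change into these parts, and a longer chain such as 5-propyl would test how much room there is beyond the ethyl group.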